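Chloro to Trifluoromethyl on a Weakly Cytotoxic Series

A few compounds are considered here, and "the series" means these few. Any claim that something is new, unique, unknown or untested is made for them only; others in the source may bear on it.

Three measured compounds and one unmeasured compound share a core and were examined in a functional assay on MDA-MB-468 cells (Homo sapiens) for cytotoxicity, read by sulforhodamine B assay, with a stated time of 48 h; a higher number here means a weaker inhibitor of growth, a lower number a stronger inhibitor of growth. Compound 1 `O=C1C(=O)N(CN2CCN(c3ccnc4cc(Cl)ccc34)CC2)c2cccc(Br)c21` gives 15900 nM. Compound 2 `O=C1C(=O)N(CN2CCN(c3ccnc4cc(C(F)(F)F)ccc34)CC2)c2cccc(Br)c21` differs from compound 1 by trifluoromethyl in place of chloro on an aromatic carbon, and in this assay compound 2 gives 52200 nM, a step that is a 3.3-fold higher number from compound 1 to compound 2 (0.52 log units; beyond the scatter). Compound 3 `NC(=S)N/N=C1/C(=O)N(CN2CCN(c3ccnc4cc(Cl)ccc34)CC2)c2cccc(Cl)c21` gives 57600 nM in this assay; how its core differs from the core of compound 1 is not broken down here. The values of compound 3 and compound 2 fall within the scatter of each other, whereas compound 3 and compound 1 lie beyond it.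

Compound 4 `NC(=S)N/N=C1/C(=O)N(CN2CCN(c3ccnc4cc(C(F)(F)F)ccc34)CC2)c2cccc(Cl)c21` differs from compound 3 by trifluoromethyl in place of chloro on an aromatic carbon, the same change as from compound 1 to compound 2. Resting on the size of a 3.3-fold higher number from compound 1 to compound 2 (0.52 log units; beyond the scatter), the step expected from compound 3 is a 2.6-fold higher number from compound 3 to compound 4 (0.42 log units; beyond the scatter). Compound 4 is therefore estimated at 150000 nM in this assay, with a plausible span from 60000 nM to 400000 nM, and a real chance that the assay reports only a limit.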

Compound 4, concentration for 50% growth inhibition: 23000 nM
Estimate against measurement, compound 4: 6.5-fold (0.81 log units) above, outside the stated range (below it).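

In this assay, trifluoromethyl in place of chloro gives a 2.5-fold lower number from compound 3 to compound 4 (0.40 log units; beyond the scatter), so the direction seen on the core of compound 1 does not carry over to the core of compound 3. Set side by side, the two results differ in direction and the gap between them is larger than chance scatter would readily explain: the same change on two cores in this assay, a 3.3-fold higher number (0.52 log units; beyond the scatter) from compound 1 to compound 2 and a 2.5-fold lower number (0.40 log units; beyond the scatter) from compound 3 to compound 4, 8.2-fold (0.91 log units) apart, beyond the scatter of two such steps Within these two pairs, then, a step measured on one core cannot be transferred to the other in either size or direction, but this does not show which difference between the cores is responsible, and two pairs set no rule for the wider series.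

The compounds shown leave open whether the reversal follows the bromo or chloro substituent on the core or the thiosemicarbazone in place of a carbonyl, as these two differences travel together in all four compounds. Also open, as far as these compounds go, is how another group at the same place, such as methoxy or a nitrile, would behave on either core.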